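Diaryl urea triazole series: ortho substituent swap on the N-aryl ring

The source may hold more compounds than are shown below. What is called first, only, known or untested is meant among the compounds shown, and "the series" means these compounds.

Measured so far:
compound 1, `Cc1cccc(-n2cc(COc3cccc(NC(=O)Nc4ccc(Cl)c(C(F)(F)F)c4)c3)nn2)c1`, 7270 nM
compound 2, `O=C(Nc1cccc(OCc2cn(-c3ccccc3Br)nn2)c1)Nc1ccc(Cl)c(C(F)(F)F)c1`, 2810 nM

Going by the values given here, in a functional assay on HepG2 cells (Homo sapiens) for inhibition, read by MTT assay, with a stated time of 72 h (on this read-out lower numbers stand for stronger inhibition and higher numbers for weaker inhibition), compound 2 gives the lowest of the two numbers; the only step measured, a 2.6-fold lower number from compound 1 to compound 2 (0.41 log units; beyond the scatter), is modest. Compound 3, `COc1ccccc1-n1cc(COc2cccc(NC(=O)Nc3ccc(Cl)c(C(F)(F)F)c3)c2)nn1`, carries methoxy in place of bromo on an aromatic carbon. Among the compounds with values here, no measured step changes this group, so the step from compound 1 to compound 2 is the sole reference and it does not bear on it directly; a step within the scatter, or at most a modest weakening, is expected. Compound 3 is estimated at 4000 nM, within 1500 nM to 11000 nM, an expected step of a 1.4-fold higher number from compound 2 to compound 3 (0.15 log units; within the scatter).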

Compound 3, half-maximal inhibitory concentration: 11300 nM
Beside the measured number, compound 3's estimate is 2.8-fold (0.45 log units) below it; measured number outside the range, above it.
By their numbers in this assay, from the lowest: compound 2; then compounds 1 and 3 (each within the scatter of the next).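

In this assay, the group on this aromatic carbon, ortho to a large group, matters: methoxy in place of bromo gives a 4.0-fold higher number from compound 2 to compound 3 (0.60 log units; beyond the scatter) and so gives up the lower number seen with 2-bromophenyl. Set against 3-methylphenyl, 2-methoxyphenyl gives a 1.6-fold higher number from compound 1 to compound 3 (0.19 log units; within the scatter) and does not separate from it, so only bromo stands apart among these three compounds. No evidence on hand accounts for the difference between bromo and methoxy.

As far as these compounds go, whether bromo is specifically favoured here remains open. The shown compounds do not tell how a chloro, an amine or a longer ether chain at this place would compare.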